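From Compound 2 to Compound 4: A Longer Chain

The compounds below may be only part of what the source reports. "The series", "measured", "known", "first", "only" and "open" are said of these compounds alone.

In a functional assay on HeLa cells (Homo sapiens) for inhibition, read by trypan blue exclusion, with a stated time of 72 h (on this read-out lower numbers stand for stronger inhibition of growth and higher numbers for weaker inhibition of growth), compound 1 `CCCn1c(-c2ccc(O)cc2)c(C)c2ccccc21` gives > 20000 nM, which is a limit of the assay and not a number. Compound 3 `COc1ccc2c(c1)c(C)c(-c1ccc(OC)c(OC)c1)n2CCCCOc1ccccc1` gives > 20000 nM, which is also a limit. Among the measured compounds shown here, compound 2 `CCCn1c(-c2ccc(O)cc2)c(C)c2cc(O)ccc21` gives 7900 nM, the only true number in this small set, so it is the single firm starting point.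

Compound 4 `Cc1c(-c2ccc(O)cc2)n(CCCCOc2ccccc2)c2ccc(O)cc12` keeps the hydroxy groups of compound 2 but alters the chain on the aromatic nitrogen. The change is phenoxymethyl in place of hydrogen on a saturated chain carbon, three bonds along the chain from an aromatic nitrogen, which can also be read as methyl to 2-phenoxyethyl.

For the measured compounds named here, no measured step tests this chain change directly. Going by the values given here, the one measured step, an at least 2.5-fold lower number from compound 1 to compound 2 (0.40 log units; beyond the scatter), was a modest gain from adding a hydroxy group, and compound 4 retains that group. Compound 3 has the same chain end but no hydroxy group at all, so it offers only a weak hint. The picture is also restricted by the limit of > 20000 nM in this assay, at which 2 of the 3 values shown sit.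

No shift beyond the usual scatter is therefore expected in this assay, though with real uncertainty in either direction. The expected step is a 1.3-fold lower number from compound 2 to compound 4 (0.12 log units; within the scatter). For compound 4, the estimated value is 6000 nM, with an expected range from 1500 nM to 20000 nM.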

Compound 4, concentration for 50% growth inhibition: 4000 nM
Beside the measured number, compound 4's estimate is 1.5-fold (0.18 log units) above it; measured number inside the range.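

In this assay, the chain change gives a 2.0-fold lower number from compound 2 to compound 4 (0.30 log units; within the scatter), so this step cannot be read as either a gain or a loss. It does show something new: a saturated chain carbon, three bonds along the chain from an aromatic nitrogen, can carry phenoxymethyl, with its whole aromatic ring, while the hydroxy groups stay in place and the compound still gives a true number, with no shift beyond the scatter. Among the compounds shown here, the earlier compounds could not show this, as the only other compound with this chain end is compound 3, which gives > 20000 nM, a limit of the assay and not a number.

The compounds shown leave open whether a different group at the end of this chain, such as an amine or a carboxylic acid, or a longer chain, would move the number beyond the scatter, and how much each hydroxy group contributes when the phenoxy end is present. Any wider reading of the series also remains narrow: the limit of > 20000 nM in this assay, at which 2 of the 4 values shown sit.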